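This account rests on a few compounds, and the source may have more. Where it says the series, first, only, none or still open, it means among the compounds named here.

Of the compounds shown here, three have been measured in a functional assay on DU-145 cells (Homo sapiens) for inhibition, read by trypan blue exclusion, with a stated time of 96 h; on this read-out lower numbers stand for stronger inhibition of growth and higher numbers for weaker inhibition of growth. Compound 1 `O=C(/C(=C\c1ccc(Br)cc1)SCc1ccc(Cl)cc1)c1ccc(Br)cc1` gives 1000 nM, the lowest of the three numbers. Compound 3 `Cc1ccc(S(=O)(=O)/C(=C/c2ccc(C)s2)C(=O)c2ccc(Br)cc2)cc1` gives 25000 nM, and compound 2 `O=C(/C(=C\c1c(O)cc(O)cc1O)S(=O)(=O)c1ccccc1Br)c1ccc(Br)cc1` gives 50000 nM. Both of these lie well beyond the scatter from compound 1, but each differs from it in more than one place, so neither isolates a single change.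

Compound 4 `COc1ccc(/C=C(/SCc2ccc(Cl)cc2)C(=O)c2ccc(Br)cc2)cc1O` keeps the rest of compound 1 and has 3-hydroxy-4-methoxyphenyl in place of 4-bromophenyl on a double-bonded chain carbon bound to a double-bonded chain carbon. For the measured compounds named here, no measured pair shows what a single change of this kind does, so the starting point is compound 1 at 1000 nM, and the uncertainty is wide. A modest shift towards stronger inhibition of growth is expected in this assay, and the expected step is a 2.5-fold lower number from compound 1 to compound 4 (0.40 log units; beyond the scatter). For compound 4 the estimated value is 400 nM, with an expected range from 50 nM to 3000 nM.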

Compound 4, concentration for 50% growth inhibition: 1000 nM
Estimate against measurement, compound 4: 2.5-fold (0.40 log units) below; measured number inside the range.
By their numbers in this assay, from the lowest: compounds 1 and 4 (each within the scatter of the next); then compounds 3 and 2 (each within the scatter of the next).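

At this place, on a double-bonded chain carbon bound to a double-bonded chain carbon, replacing 4-bromophenyl with 3-hydroxy-4-methoxyphenyl gives no change at the digits printed from compound 1 to compound 4 (within the scatter) in this assay. For the compounds shown here, this is the first single change that can be read, and it shows that, for this pair, the bromine can give way to a larger aryl group carrying a hydrogen-bond donor and hydrogen-bond acceptors with no shift in the number beyond the scatter. Nothing shown explains why the number holds across this change.

The compounds shown leave open whether the hydroxy and methoxy groups matter separately, since they enter together. They also leave open whether a carboxylic acid or an amine on the phenyl ring at this place would fit as well.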